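This account rests on a few compounds, and the source may have more. Where it says the series, first, only, none or still open, it means among the compounds named here.

Measured compounds: compound 1 `Cc1ccccc1-n1nc(C)c2c1NC(=O)[C@H](C)S[C@@H]2c1ccc(-c2ccoc2)cc1` gives 40% in an assay on isolated protein for agonist activity at Bile acid receptor (Homo sapiens), read by AlphaScreen, with a stated time of 30 min; a lower number here means a smaller maximal response, a higher number a larger maximal response; compound 2 `CCCc1ccccc1-n1nc(C)c2c1NC(=O)[C@H](C)S[C@@H]2c1ccc(Oc2ccccc2)cc1` gives 240%; compound 3 `Cc1ccccc1-n1nc(C)c2c1NC(=O)[C@H](C)S[C@@H]2c1ccc(-c2ccsc2)cc1` gives 68%.

Compound 3 stands second highest of the three: compound 1 sits lower, the step being a number 28 percentage points higher from compound 1 to compound 3 (beyond the scatter), while compound 2 lies far above it.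

Compound 4 `CCOc1cccc(-c2ccc([C@H]3S[C@@H](C)C(=O)Nc4c3c(C)nn4-c3ccccc3C)cc2)c1` differs from compound 3 by 3-ethoxyphenyl in place of thiophen-3-yl on an aromatic carbon. For the measured compounds named here, the only measured step, from compound 1 to compound 3, swaps one five-membered ring for another and is modest in size; no measured pair tests a six-membered ring with an ether at this position. Compound 2 carries an aryl ether and shows the largest response, but it also differs elsewhere, so it gives only loose guidance.

A larger maximal response is expected for compound 4, the step of a number 42 percentage points higher from compound 3 to compound 4 (beyond the scatter) being upward but uncertain. Compound 4 is estimated at 110%, between 55% and 200%.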

Compound 4, largest response reached (reported as efficacy), in percent of the reference or control that the assay uses: 13%
The estimate for compound 4 lay 97 percentage points above the measured number; measured number outside the range, below it.
By their numbers in this assay, from the lowest: compound 4; then compound 1; then compound 3; then compound 2.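

In this assay this position does not reward size alone: 3-ethoxyphenyl, with 9 heavy atoms against 5 for thiophen-3-yl, gives a number 55 percentage points lower from compound 3 to compound 4 (beyond the scatter) on the same core. Against furan-3-yl the change gives a number 27 percentage points lower from compound 1 to compound 4 (beyond the scatter) and so leaves both five-membered aromatic rings above this six-membered one. No available evidence accounts for the drop.

Open, as far as these compounds go, is whether the loss follows the six-membered ring or the ethoxy group. A plain phenyl, or a phenyl carrying an amine in place of ethoxy, would separate the two.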